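The compounds below may be only part of what the source reports. "The series", "measured", "known", "first", "only" and "open" are said of these compounds alone.

Compounds measured so far:
compound 1, `c1ccc(-c2csc(Nc3cccc4ccccc34)n2)cc1`, 5500 nM
compound 2, `CC(C)(C)c1csc(Nc2ccccc2)n1`, 4500 nM
compound 3, `Cc1ccccc1Nc1nc(C(C)(C)C)cs1`, 900 nM

In an assay on CCRF-CEM cells for displacement of a labelled ligand from C-C chemokine receptor type 4 (Homo sapiens) (on this read-out higher numbers stand for weaker inhibition and lower numbers for stronger inhibition), compound 3 stands lowest of the three numbers, with compound 2 nearest and compound 1 furthest, both gaps beyond the scatter. For the measured compounds named here, the only single-change step measured is a 5.0-fold lower number from compound 2 to compound 3 (0.70 log units; beyond the scatter), a methyl taking the place of a hydrogen on an aromatic carbon. Compound 4, `CC(C)c1ccccc1Nc1nc(C(C)(C)C)cs1`, differs from compound 3 by isopropyl in place of methyl on an aromatic carbon. Going by the values given here, no measured pair tests a methyl-to-isopropyl exchange, so that earlier step is the only guide, and it speaks for the same direction at most; a step in this assay is expected to be small, a 1.3-fold lower number from compound 3 to compound 4 (0.11 log units; within the scatter), and may stay within the scatter. The estimate for compound 4 is 700 nM, with a range from 250 nM to 2000 nM.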

Compound 4, half-maximal inhibitory concentration: 440 nM
Estimate against measurement, compound 4: 1.6-fold (0.20 log units) above; the measured number falls inside the stated range.
By their numbers in this assay, from the lowest: compound 4; then compound 3; then compounds 2 and 1 (each within the scatter of the next).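

At the aromatic carbon ortho to a large group, the gain seen with methyl is not the limit in this assay: isopropyl in place of methyl gives a 2.0-fold lower number from compound 3 to compound 4 (0.31 log units; beyond the scatter) and isopropyl in place of hydrogen gives a 10-fold lower number from compound 2 to compound 4 (1.01 log units; beyond the scatter) in all. Across hydrogen, methyl and isopropyl at this position, the number falls with each larger group. Nothing measured here accounts for this gain.

Going by these compounds, whether cyclohexyl would lower the number further remains open. So does whether a methoxy group or an amine could stand in place of isopropyl.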